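Piperidinylmethyl dichlorobenzamides: amine substituent change

A few compounds are considered here, and "the series" means these few. Any claim that something is new, unique, unknown or untested is made for them only; others in the source may bear on it.

Measured compounds:
compound 1, `O=C(NCC1CCN(Cc2ccc(Br)nc2)CC1)c1cc(Cl)cc(Cl)c1`, 552 nM
compound 2, `CC(C)(C)CCN1CCC(CNC(=O)c2cncc(Br)c2)CC1`, 2550 nM

In an assay on isolated protein for inhibition of Voltage-dependent T-type calcium channel subunit alpha-1I (Homo sapiens), read by FLIPR (on this read-out higher numbers stand for weaker inhibition and lower numbers for stronger inhibition), compound 1 gives 552 nM. Compound 2 gives 2550 nM, a higher number, and the gap between the two lies beyond the scatter, so compound 1 stands at the lower of the two numbers. For the measured compounds named here, compound 2 differs from compound 1 in more than one place, so the two values show only that the pair is separated, not which change is responsible.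

Compound 3, `CC(C)(C)NC(=O)CN1CCC(CNC(=O)c2cc(Cl)cc(Cl)c2)CC1`, has not been measured. It differs from compound 1 in one place: (tert-butyl)carbamoyl in place of 6-bromopyridin-3-yl on a saturated chain carbon bound to an amine nitrogen in a ring. Going by the values given here, no measured pair isolates this change, so there is no step to draw on. With the ring substituent removed from the chain on the ring amine nitrogen, the working assumption is a move towards a higher number, of moderate size; the step of a 2.4-fold higher number from compound 1 to compound 3 (0.37 log units; beyond the scatter) is the expected change. Compound 3 is accordingly estimated at 1300 nM, with a range from 400 nM to 4500 nM in this assay, the range wide because nothing measured constrains this substituent.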

Compound 3, half-maximal inhibitory concentration: 22 nM
The estimate for compound 3 lay 59-fold (1.77 log units) above the measured number; measured number below the stated range.
By their numbers in this assay, from the lowest: compound 3; then compound 1; then compound 2.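

In this assay, for the compounds shown here, (tert-butyl)carbamoyl in place of 6-bromopyridin-3-yl on a saturated chain carbon bound to an amine nitrogen in a ring gives a 25-fold lower number from compound 1 to compound 3 (1.40 log units; beyond the scatter), the first single-place reading and a large step beyond the scatter. This place is therefore highly responsive to the group it carries, and an aromatic ring in that group is not needed for a low number: compound 3 reaches 22 nM with no ring in the entering group, while the heavy-atom count stays at 7 and the entering group adds a double bond outside aromatic rings and a hydrogen-bond donor. No supporting measurement is available to explain the step.

Going by these compounds alone, the single pair does not separate the contributions of the tert-butyl group, the carbonyl and the amide hydrogen, so a cyclopropyl amide, a tertiary N-methyl amide or a ketone at this place would be informative. Also open, from the compounds shown here alone, is whether a longer chain between the ring amine nitrogen and the carbonyl would keep a number close to that of compound 3.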